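The source may report more compounds than this note shows. Statements on the series, on what has been measured and on what is new or still open speak of the compounds shown alone.

Working notes on the riboside series sharing one fused core, read in a functional assay on HL-60 cells (Homo sapiens) for antiproliferative activity, read by XTT assay, with a stated time of 72 h; a lower number here means a stronger inhibitor, a higher number a weaker inhibitor. Among the compounds with values here, compound 1 `COc1ncnc2c1c(I)cn2[C@@H]1O[C@H](CO)[C@@H](O)[C@H]1O` carries iodo on the five-membered ring of that core; in this assay compound 1 gives 2300 nM, which is the only number among the three values shown, the other two sitting at the limit of > 20000 nM in this assay, at which 2 of the 3 values shown sit. Compound 2 `Nc1nc2c(c(-c3ccccc3)cn2[C@@H]2O[C@H](CO)[C@@H](O)[C@H]2O)c(=O)[nH]1` differs from compound 1 both in the group on that ring and in the substitution of the core, and in this assay compound 2 returns only the limit > 20000 nM. Compound 3 `COc1nc(N)nc2c1c(-c1ccccc1)cn2[C@@H]1O[C@H](CO)[C@@H](O)[C@H]1O` likewise differs in more than one place, and in this assay compound 3 returns only the limit > 20000 nM. Within the data shown here, neither pair with compound 1 differs in one place alone, so no measured single-change step is available; the two limits show only that those compounds stay beyond the range read.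

Compound 4 `COc1ncnc2c1c(-c1ccco1)cn2[C@@H]1O[C@H](CO)[C@@H](O)[C@H]1O` keeps the core of compound 1 and changes one group: furan-2-yl in place of iodo on an aromatic carbon. For compound 4 a drift toward weaker inhibition in this assay is expected, of a size barely beyond the scatter, because two of the three values shown sit at the limit of > 20000 nM in this assay, at which 2 of the 3 values shown sit. The expected step is a 1.7-fold higher number from compound 1 to compound 4 (0.24 log units; within the scatter). For compound 4 the estimate in this assay is 4000 nM, with a range from 800 nM to 20000 nM.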

Compound 4, half-maximal inhibitory concentration: 100 nM
The estimate for compound 4 lay 40-fold (1.60 log units) above the measured number; measured number outside the range, below it.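

In this assay, furan-2-yl in place of iodo on an aromatic carbon of the five-membered aromatic ring gives a 23-fold lower number from compound 1 to compound 4 (1.36 log units; beyond the scatter), the only single-change step shown in the series. This position is therefore not merely tolerant of substitution: on the core of compound 1, the number responds strongly to the group placed there, and a five-membered aromatic ring with 5 heavy atoms is accepted in place of a single iodine atom. Compound 2 and compound 3 each differ from compound 4 in more than one place and give only limits, so no step to either can be read and they add nothing to this comparison: the limit of > 20000 nM in this assay, at which 2 of the 4 values shown sit.

From the compounds shown here alone, with one step at this position, it remains open whether the gain depends on the ring oxygen of furan-2-yl or on the presence of any five-membered aromatic ring, a question that thiophen-2-yl at the same carbon would address. Also open, going by these compounds, is how an amine or a longer alkyl chain at this carbon would read on the core of compound 1, and whether the step holds on the other substitution patterns of the core.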